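The compounds below may be only part of what the source reports. "The series", "measured", "known", "first", "only" and "open" are said of these compounds alone.

Three compounds share the same kind of structural change. Compound 1 `Cc1nc2cnccc2n1CC1CCN(C(=O)CC(C)(C)c2ccc(N)cc2)CC1` gives 0.099 mg/kg in a functional assay on the whole organism (arterial blood) with Rattus norvegicus as the target; a higher number here means that more compound is needed for the effect, a lower number that less compound is needed. Compound 3 `Cc1nc2cnccc2n1CC1CCN(C(=O)CC(C)(C)c2ccc(/N=N\c3ccc(O)c(C(=O)O)c3)cc2)CC1` carries a larger group in place of the amino group of compound 1, the change being (a group of 12 heavy atoms (7 carbon, 2 nitrogen, 3 oxygen; one six-membered aromatic ring of carbon only) in place of one nitrogen atom, on an aromatic carbon), and in this assay compound 3 gives 0.11 mg/kg; the step is a 1.1-fold higher number from compound 1 to compound 3 (0.05 log units; within the scatter). Compound 2 `CCOC(=O)[C@H](CC(C)C)N(Cc1ccc(N)cc1)S(=O)(=O)c1ccc(Cn2c(C)nc3cnccc32)cc1` is built on a different core, and how the two cores differ is not broken down here. In this assay compound 2 gives 0.033 mg/kg. Compound 4 `CCOC(=O)[C@H](CC(C)C)N(Cc1ccc(/N=N\c2ccc(O)c(C(=O)O)c2)cc1)S(=O)(=O)c1ccc(Cn2c(C)nc3cnccc32)cc1` has not yet been measured; it differs from compound 2 by a group of 12 heavy atoms (7 carbon, 2 nitrogen, 3 oxygen; one six-membered aromatic ring of carbon only) in place of one nitrogen atom, on an aromatic carbon, which is the same kind of change that took compound 1 to compound 3. For compound 4 an essentially unchanged result is expected, because the earlier instance of the change gave a 1.1-fold higher number from compound 1 to compound 3 (0.05 log units; within the scatter), a step that lies within the usual scatter of repeated measurements. The expected step is a 1.1-fold higher number from compound 2 to compound 4 (0.03 log units; within the scatter). Compound 4 is therefore estimated at 0.035 mg/kg, most likely between 0.015 mg/kg and 0.08 mg/kg.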

Compound 4, dose for 50% inhibition: 1.31 mg/kg
Compound 4: the middle estimate sits 37-fold (1.57 log units) below what was measured; the measured number lies above the stated range.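

In this assay, the same swap of the amino group for the larger group behaves differently on the core of compound 2, giving a 40-fold higher number from compound 2 to compound 4 (1.60 log units; beyond the scatter) even though it changed little on the core of compound 1. The outcome of this change on one core therefore cannot simply be carried over to the other in this series: the same change on two cores in this assay, a 1.1-fold higher number (0.05 log units; within the scatter) from compound 1 to compound 3 and a 40-fold higher number (1.60 log units; beyond the scatter) from compound 2 to compound 4, 36-fold (1.55 log units) apart, beyond the scatter of two such steps. This comparison rests on a single pair of compounds per core, so it does not show which feature of the two cores separates them, or which outcome would be the more typical on a further core.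

The compounds shown leave open which part of the entering group goes with the higher number on the core of compound 2. They also leave open whether a smaller group in the same place, such as a plain acetamide or a phenyl ring without the hydroxyl and the carboxylic acid, would give a step like the large one or like the small one.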